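This account rests on a few compounds, and the source may have more. Where it says the series, first, only, none or still open, it means among the compounds named here.

Compound 1 `Cc1cc(-c2cc(Cl)cc(C)c2/C=C/[C@@H]2C[C@@H](O)CC(=O)O2)ccc1F` — 6 nM
Compound 2 `Cc1cc(-c2cc(Cl)cc(Cl)c2/C=C/[C@@H]2C[C@@H](O)CC(=O)O2)ccc1F` — 29 nM
Compound 3 `Cc1cc(C)cc(-c2cc(Cl)cc(Cl)c2/C=C/[C@@H]2C[C@@H](O)CC(=O)O2)c1` — 13 nM

In an assay for inhibition of 3-hydroxy-3-methylglutaryl-coenzyme A reductase (Rattus norvegicus) (on this read-out lower numbers stand for stronger inhibition and higher numbers for weaker inhibition), compound 2 gives the highest of the three numbers; compound 3 lies nearest, as shown by a 2.2-fold lower number from compound 2 to compound 3 (0.35 log units; beyond the scatter), and compound 1 lies furthest, as shown by a 4.8-fold higher number from compound 1 to compound 2 (0.68 log units; beyond the scatter). Compound 4 `Cc1cc(-c2cccc(Cl)c2/C=C/[C@@H]2C[C@@H](O)CC(=O)O2)ccc1F` differs from compound 2 by hydrogen in place of chloro on an aromatic carbon. The measured step that bears on this is the one at the same aromatic carbon, a 4.8-fold higher number from compound 1 to compound 2 (0.68 log units; beyond the scatter), where chloro replaced methyl; the step of a 2.2-fold lower number from compound 2 to compound 3 (0.35 log units; beyond the scatter) concerns a different group. For the measured compounds named here, no measured pair shows hydrogen at this place. Since compound 1, with methyl at this carbon, gives 6 nM, the removal of chloro is expected to lower the number from that of compound 2, with some uncertainty. The expected step is a 2.4-fold lower number from compound 2 to compound 4 (0.38 log units; beyond the scatter). Compound 4 is therefore expected to give about 12 nM in this assay, within a range of 4 nM to 40 nM.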

Compound 4, half-maximal inhibitory concentration: 30 nM
Estimate against measurement, compound 4: 2.5-fold (0.40 log units) below, and the stated range covers the measured number.
By their numbers in this assay, from the lowest: compound 1; then compound 3; then compounds 2 and 4 (each within the scatter of the next).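

In this assay, hydrogen and chloro on this aromatic carbon cannot be told apart (a 1.0-fold higher number from compound 2 to compound 4 (0.01 log units; within the scatter)). Of the three groups seen at this carbon, only methyl stands apart: compound 1, with methyl, gives 6 nM, while compound 4, with hydrogen, gives 30 nM. The higher number of compound 2 relative to compound 1 therefore does not set chloro apart from an unsubstituted carbon.

As far as these compounds go, whether an ethyl or a methoxy group at this carbon would behave like methyl remains open. Nothing available explains why methyl stands apart.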